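The source may report more compounds than this note shows. Statements on the series, on what has been measured and on what is new or still open speak of the compounds shown alone.

Of the compounds shown here, two built on a shared core have so far been tested in a functional assay on HeLa cells (Homo sapiens) for inhibition; on this read-out lower numbers stand for stronger inhibition and higher numbers for weaker inhibition. Compound 1 `Oc1ccccc1-c1cc(-c2ccc(F)cc2)cc(-c2ccccc2O)n1` gives only a limit of the assay there, > 50000 nM. Compound 2 `Oc1cccc(-c2cc(-c3cccc(F)c3)cc(-c3ccccc3O)n2)c1` also gives only a limit in this assay, > 50000 nM. Where compound 2 stands is thus known just as a limit, and both values sit at the limit of > 50000 nM in this assay, at which 2 of the 2 values shown sit, so no ordering between the two is possible.

Compound 3 `Oc1cccc(-c2cc(-c3ccc(F)cc3)cc(-c3ccccc3O)n2)c1` has not yet been measured. It differs from compound 2 in one place: 4-fluorophenyl in place of 3-fluorophenyl on an aromatic carbon. For the measured compounds named here, no step between measured compounds exists to gauge such a change, and because both known values are limits, no direction can be read from them. The step is expected to be small or none beyond the scatter, a step that the limit leaves unreadable from compound 2 to compound 3. Compound 3 is therefore estimated to give 70000 nM, with a range from 15000 nM to 300000 nM.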

Compound 3, half-maximal inhibitory concentration: > 50000 nM
Compound 3: no number, only a limit; the forecaster's own chance of this, stated with the estimate: 85%; the middle value does not contradict the limit.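

For the compounds shown here, compound 3 joins compound 1 and compound 2 with a limit rather than a number, so no step among the three can be read: the limit of > 50000 nM in this assay, at which 3 of the 3 values shown sit.

Left open is whether any compound on this shared core gives a measurable value in this assay at all, and so whether moving the fluoro or hydroxy group changes inhibition.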